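The compounds below may be only part of what the source reports. "The series", "measured", "known", "first", "only" and "open" are said of these compounds alone.

Measured so far in a functional assay on B16-F0 cells (Mus musculus) for inhibition, read by CCK-8 assay, with a stated time of 48 h; a higher number here means a weaker inhibitor, a lower number a stronger inhibitor:

Compound 1 `COc1cc(-c2ccnc3cc(-c4ccc(F)cc4)nn23)cc(OC)c1OC`: 4540 nM
Compound 2 `COc1cc(-c2ccnc3cc(-c4ccc(C)cc4)nn23)cc(OC)c1OC`: 21 nM
Compound 3 `COc1cc(-c2ccnc3cc(-c4cccc(C#N)c4)nn23)cc(OC)c1OC`: > 10000 nM

All three share one core and differ only in the aromatic ring attached to it. Compound 3 gives > 10000 nM, which is a limit of the assay and not a number. This is the limit of > 10000 nM in this assay, at which 1 of the 3 values shown sits, so compound 3 has no exact place in the series and is known only to lie beyond that limit.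

The next compound is compound 4 `COc1cc(-c2ccnc3cc(-c4ccccc4)nn23)cc(OC)c1OC`, which has hydrogen in place of cyano on an aromatic carbon, turning 3-cyanophenyl into phenyl: hydrogen in place of cyano on an aromatic carbon.

For the measured compounds named here, no measured step removes a cyano group alone, so the closest evidence comes from the two steps that arrive at 3-cyanophenyl. These are an at least 2.2-fold higher number from compound 1 to compound 3 (0.34 log units; beyond the scatter) and an at least 470-fold higher number from compound 2 to compound 3 (2.67 log units; beyond the scatter). Both end at compound 3 with a higher number, so losing the cyano group should lower the number, probably by a size somewhere between those two steps. The range must stay wide, since a single group swap gave a 220-fold lower number from compound 1 to compound 2 (2.33 log units; beyond the scatter).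

The expected change is an at least 16-fold lower number from compound 3 to compound 4 (1.22 log units; beyond the scatter). For compound 4 the estimated value is 600 nM, with an expected range from 60 nM to 6000 nM.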

Compound 4, half-maximal inhibitory concentration: 4730 nM
The estimate for compound 4 lay 7.9-fold (0.90 log units) below the measured number, and the stated range covers the measured number.
By their numbers in this assay, from the lowest: compound 2; then compounds 1 and 4 (each within the scatter of the next). At a limit, above all of these: compound 3.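

In this assay, for the compounds shown here, the plain phenyl ring of compound 4 gives the series an unsubstituted reference, and against it only one of the groups stands out: hydrogen in place of methyl gives a 230-fold higher number from compound 2 to compound 4 (2.35 log units; beyond the scatter), while hydrogen in place of fluoro gives a 1.0-fold higher number from compound 1 to compound 4 (0.02 log units; within the scatter). So, among these compounds, the high potency of compound 2 goes with the methyl group, and a fluoro group on the ring does not produce it. Hydrogen in place of cyano gives an at least 2.1-fold lower number from compound 3 to compound 4 (0.32 log units; beyond the scatter), but this size is only a minimum, as compound 3 stands at a limit of the assay and not at a number: the limit of > 10000 nM in this assay, at which 1 of the 4 values shown sits.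

The compounds shown leave open whether methyl is unique or whether an ethyl, methoxy or chloro group on the same carbon would match it. They also do not separate the identity of the group from its place on the ring, which a comparison of 3-methylphenyl and 4-cyanophenyl rings could begin to do.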